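This account rests on a few compounds, and the source may have more. Where it says the series, first, only, none or still open, it means among the compounds named here.

Working notes on the series, cytotoxicity read-out. In an ADME assay on J744 cells (Mus musculus) for cytotoxicity, read by MTT assay, with a stated time of 48 h (a higher number here means a weaker inhibitor, a lower number a stronger inhibitor), compound 1 `Cc1c(C(=O)N/N=C/c2ccco2)no[n+]1[O-]` gives > 400000 nM, which is a limit of the assay and not a number. Compound 2 `Cc1nc2ccccn2c1C(=O)N/N=C/c1no[n+]([O-])c1C` gives > 400000 nM, also a limit. Compound 3 `Cc1c(C(=O)N/N=C/c2cccs2)no[n+]1[O-]` gives > 400000 nM, again a limit. Compound 1 therefore has no numerical position in the series, and the whole record is the limit of > 400000 nM in this assay, at which 3 of the 3 values shown sit.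

The next entry is compound 4 `Cc1c(C(=O)N/N=C/c2ccc([N+](=O)[O-])o2)no[n+]1[O-]`, which differs from compound 1 by nitro in place of hydrogen on an aromatic carbon, next to the ring oxygen. Within the data shown here, the one measured step within reach is a step that the two limits leave unreadable from compound 1 to compound 3. Among the measured compounds shown here, it concerns the same part of the molecule but gives no size, and no measured pair contains the nitro group.

The size of the change in this assay thus cannot be read from the data. With compound 1 at > 400000 nM, any readable result for compound 4 would have to lie toward lower numbers, and another limit remains quite possible. For compound 4 the expected value is 150000 nM, with an estimated range from 30000 nM to 400000 nM. The estimated step is an at least 2.6-fold lower number from compound 1 to compound 4 (0.42 log units; beyond the scatter).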

Compound 4, half-maximal inhibitory concentration: 96000 nM
The estimate for compound 4 lay 1.6-fold (0.19 log units) above the measured number; the measured number falls inside the stated range.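

In this assay, among these compounds, nitro in place of hydrogen gives the only readable step, an at least 4.1-fold lower number from compound 1 to compound 4 (0.61 log units; beyond the scatter), and this step is a lower bound on the change. It shows that a substitution on this aromatic carbon of the five-membered aromatic ring with 1 oxygen, next to the ring oxygen and two ring bonds from the ring atom that bears a large group, can bring the read-out to a measurable number, whereas the step from furan-2-yl to thiophen-2-yl cannot be read. Compound 1, compound 2 and compound 3 each remain at a limit of the assay, not a number: the limit of > 400000 nM in this assay, at which 3 of the 4 values shown sit.

The compounds shown leave open how far the change reaches, since only one group has been seen at this position, and an amine, a carboxylic acid or a methyl group there could either give a number or stay at the limit. Also open, going by these compounds, is whether nitro at the corresponding place on the thiophen-2-yl ring of compound 3 would give a comparable step, and how the full size of the step from the hydrogen parent would read.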